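Aryl swap on the ring nitrogen and tolerance in macrophage-like cells

A few compounds are considered here, and "the series" means these few. Any claim that something is new, unique, unknown or untested is made for them only; others in the source may bear on it.

Compound 1 `c1ccc(-c2nc3ccccn3c2NCC2CC2)nc1` — an ADME assay on THP-1 cells (Homo sapiens) for cytotoxicity; a higher number here means that more compound is tolerated, a lower number that less compound is tolerated: 19400 nM
Compound 2 `Fc1cccc(Nc2c(-c3ccccn3)nc3ccccn23)c1` — this assay: > 50000 nM (a limit of the assay, not a number)

In this assay compound 1 gives 19400 nM. For compound 2 the assay reports only its limit, > 50000 nM, so where compound 2 truly stands is known only as a floor. For the measured compounds named here, the single measured step, an at least 2.5-fold higher number from compound 1 to compound 2 (0.41 log units; beyond the scatter), is therefore itself open-ended, a consequence of the limit of > 50000 nM in this assay, at which 1 of the 2 values shown sits.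

Compound 3 `N#Cc1ccc(Nc2c(-c3ccccn3)nc3ccccn23)cc1` differs from compound 2 by 4-cyanophenyl in place of 3-fluorophenyl on a nitrogen on an aromatic ring. Going by the values given here, no measured step covers an exchange of one aryl group for another on this nitrogen; the only step known ends at the limit and concerns a different pair of groups. Compound 3 is expected to move by a number no higher from compound 2 to compound 3 (the limit leaves the size open), that is, no step beyond the scatter. Compound 3 is therefore estimated at 50000 nM, within 25000 nM to 100000 nM, most likely again reported only as a limit.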

Compound 3, half-maximal cytotoxic concentration: > 50000 nM
Compound 3: no number, only a limit; the forecaster's own chance of this, stated with the estimate: 70%; the middle value sits exactly at the limit.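

A second aryl group on this nitrogen, 4-cyanophenyl, now stands alongside 3-fluorophenyl: in this assay compound 3 also gives only a limit, > 50000 nM. Exchanging cyclopropylmethyl for 4-cyanophenyl gives an at least 2.5-fold higher number from compound 1 to compound 3 (0.41 log units; beyond the scatter), so the rise in tolerated compound is not confined to 3-fluorophenyl. The step between the two aryl compounds cannot be read, and neither can be placed above the other: the limit of > 50000 nM in this assay, at which 2 of the 3 values shown sit.

Where compound 2 and compound 3 truly stand in this assay remains open, as does how much of the tolerance depends on the aryl group itself. Also open, on these data alone, is how an amine or a carboxylic acid on the aryl ring, or a longer chain on this nitrogen, would behave in this assay.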